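Cytotoxicity notes on a shared-core series: cyanophenyl to isobutyl

The source may hold more compounds than are shown below. What is called first, only, known or untested is meant among the compounds shown, and "the series" means these compounds.

Measured so far:
- compound 1, `COc1ccc(F)cc1CNCCCNc1ccnc2cc(Cc3ccc(C#N)cc3)ccc12`: 6050 nM
- compound 2, `COc1cccc(CNCCCNc2ccnc3cc(Cc4ccc(F)cc4)ccc23)c1O`: 4780 nM

In an ADME assay on HepG2 cells (Homo sapiens) for cytotoxicity, read by luminescence, CellTiter-Glo and ATP content, with a stated time of 72 h (a lower number here means that less compound is needed, a higher number that more compound is needed for the effect), compound 1 gives 6050 nM, the highest of the two numbers in hand. Its nearest neighbour is compound 2, which in this assay gives 4780 nM; the gap between the two lies within the scatter, so no order between them can be read from these numbers. For the measured compounds named here, no pair among the measured compounds differs in one place only, so no single-change step is known for this series.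

Compound 3, `COc1ccc(F)cc1CNCCCNc1ccnc2cc(CCC(C)C)ccc12`, is not yet measured. It differs from compound 1 as follows: isobutyl in place of 4-cyanophenyl on a saturated chain carbon bound to an aromatic carbon. The group that leaves carries a six-membered aromatic ring and one hydrogen-bond acceptor; what enters has no ring and no acceptor. Going by the values given here, with no measured step of this kind to lean on, the expectation is that the step of a 1.2-fold lower number from compound 1 to compound 3 (0.08 log units; within the scatter) stays about within the scatter, with no clear direction. The estimate for compound 3 in this assay is 5000 nM, expected to fall between 1500 nM and 16000 nM.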

Compound 3, half-maximal effective concentration: 890 nM
For compound 3 the middle estimate is 5.6-fold (0.75 log units) above the measured one; the whole stated range lies above it.
By their numbers in this assay, from the lowest: compound 3; then compounds 2 and 1 (each within the scatter of the next).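

In this assay, for the compounds shown here, the place on a saturated chain carbon bound to an aromatic carbon turns out to be sensitive to the group it carries: isobutyl in place of 4-cyanophenyl gives a 6.8-fold lower number from compound 1 to compound 3 (0.83 log units; beyond the scatter), the only single-change step so far and one that lies beyond the scatter. The earlier compounds shown here could not show this, as they offered no pair differing in one place. This one change removes the six-membered aromatic ring and the nitrile together, and nothing in hand bears on why the number falls.

Which of these two losses carries the step remains open; an unsubstituted phenyl would test the nitrile alone, and a cyclohexyl would test the aromatic ring. Going by these compounds, how the number responds to chain length at this place, for instance with an n-hexyl chain, is also open.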